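This account rests on a few compounds, and the source may have more. Where it says the series, first, only, none or still open, it means among the compounds named here.

Compound 1, `Oc1cccc(/C=C/C[C@H]2C[C@@H]([C@@H](O)c3ccccc3)CO[C@@H]2c2ccccc2)c1`: 12800 nM
Compound 2, `O=[N+]([O-])c1ccccc1/C=C/C[C@H]1C[C@@H]([C@@H](O)c2ccccc2)CO[C@@H]1c1ccccc1`: 7250 nM
Compound 3, `CCCCCC/C=C/C[C@H]1C[C@@H]([C@@H](O)c2ccccc2)CO[C@@H]1c1ccccc1`: 4990 nM

All three were tested in a functional assay on HL-60 cells (Homo sapiens) for cytotoxicity, read by WST assay, with a stated time of 48 h; on this read-out lower numbers stand for stronger inhibition and higher numbers for weaker inhibition. They share one core and differ in a single group. Compound 3 carries the lowest number of the three, but it is not clearly set apart: its distance from compound 2 is a 1.5-fold lower number from compound 2 to compound 3 (0.16 log units; within the scatter), which lies within the scatter, while its distance from compound 1 is a 2.6-fold lower number from compound 1 to compound 3 (0.41 log units; beyond the scatter), a modest step beyond the scatter.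

Compound 4, `O=[N+]([O-])c1cccc(/C=C/C[C@H]2C[C@@H]([C@@H](O)c3ccccc3)CO[C@@H]2c2ccccc2)c1`, has not yet been measured. It differs from compound 3 in one place: 3-nitrophenyl in place of hexyl on a double-bonded chain carbon bound to a double-bonded chain carbon. Among the compounds with values here, two measured steps bear on this change, since both replaced an aromatic ring with hexyl. From compound 1 to compound 3 the number fell by a 2.6-fold lower number from compound 1 to compound 3 (0.41 log units; beyond the scatter), and from compound 2 to compound 3 it fell by a 1.5-fold lower number from compound 2 to compound 3 (0.16 log units; within the scatter), the latter within the scatter. The step to compound 4 runs the other way, so a somewhat higher number is expected, with the 2-nitrophenyl case suggesting it may stay within the scatter. The expected step is a 1.6-fold higher number from compound 3 to compound 4 (0.20 log units; within the scatter). Compound 4 is therefore estimated at 8000 nM, with a range from 4000 nM to 16000 nM.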

Compound 4, half-maximal inhibitory concentration: 6350 nM
Compound 4: middle estimate off by 1.3-fold (0.10 log units), on the high side; the range from low to high includes it.
By their numbers in this assay, from the lowest: compounds 3, 4, 2 and 1 (each within the scatter of the next, the first and the last beyond it).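

In this assay, 3-nitrophenyl in place of hexyl on a double-bonded chain carbon gives a small step (a 1.3-fold higher number from compound 3 to compound 4 (0.10 log units; within the scatter)), so at this place a nitro-bearing aromatic ring and a plain six-carbon chain cannot be told apart, even though the entering group adds a ring and hydrogen-bond acceptors. Within the data shown here, the comparison of 3-nitrophenyl with 2-nitrophenyl gives the first direct look at where the nitro group sits on the ring, and that step (a 1.1-fold lower number from compound 2 to compound 4 (0.06 log units; within the scatter)) also shows no readable difference. Nitro in place of hydroxy on an aromatic carbon gives a larger step that is still printed as within the scatter (a 2.0-fold lower number from compound 1 to compound 4 (0.30 log units; within the scatter)), which leaves the step from the hydroxy compound to the hexyl compound (a 2.6-fold lower number from compound 1 to compound 3 (0.41 log units; beyond the scatter)) as the only one here beyond the scatter.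

Nothing measured here gives a reason for these small differences. Going by these compounds, whether an amine or a carboxylic acid on the aromatic ring, or a longer chain in place of hexyl, would move the number clearly beyond the scatter remains open.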